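The compounds below may be only part of what the source reports. "The series", "measured", "known", "first", "only" and "open" are said of these compounds alone.

Compound 2 `CNc1ncnc2c1ncn2[C@@H]1O[C@H](CO[Si](C)(C)C(C)(C)C)[C@@]2(OS(=O)(=O)C=C2N)[C@H]1O[Si](C)(C)C(C)(C)C` stands level with compound 1 `CC(C)(C)[Si](C)(C)OC[C@H]1O[C@@H](n2cnc3c(O)ncnc32)[C@H](O[Si](C)(C)C(C)(C)C)[C@]12OS(=O)(=O)C=C2N` in a functional assay on MT4 cells (Homo sapiens) for cytotoxicity; a lower number here means that less compound is tolerated, a higher number that more compound is tolerated: compound 1 gives 14000 nM and compound 2 gives 14000 nM, so the step of no change at the digits printed from compound 1 to compound 2 (within the scatter) lies within the scatter. Compound 3 `CC(C)(C)[Si](C)(C)OC[C@H]1O[C@@H](n2cnc3c(N)ncnc32)[C@H](O[Si](C)(C)C(C)(C)C)[C@]12OS(=O)(=O)C=C2N` differs from compound 2 by hydrogen in place of methyl on a nitrogen on an aromatic ring, methylamino to amino. Among the compounds with values here, the only step measured on this series, no change at the digits printed from compound 1 to compound 2 (within the scatter), which put methylamino in place of hydroxy on an aromatic carbon, left this assay unchanged, so for the present change no step beyond the scatter is expected, no change at the digits printed from compound 2 to compound 3 (within the scatter). Compound 3 is accordingly estimated at 14000 nM in this assay, with a range from 7000 nM to 28000 nM.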

Compound 3, half-maximal cytotoxic concentration: 13000 nM
Estimate against measurement, compound 3: 1.1-fold (0.03 log units) above; low and high end bracket the measured number.
By their numbers in this assay, from the lowest: compounds 3, 1 and 2 (each within the scatter of the next).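

In this assay the loss of the methyl on the nitrogen gives a 1.1-fold lower number from compound 2 to compound 3 (0.03 log units; within the scatter) and the amino for hydroxy exchange gives a 1.1-fold lower number from compound 1 to compound 3 (0.03 log units; within the scatter) within the scatter. Hydroxy, methylamino and amino on this aromatic carbon thus read alike across the three compounds, and the methyl on the nitrogen makes no measurable difference. Nothing measured bears on the reason for this flat reading.

As far as these compounds go, whether dimethylamino or a longer alkylamino chain on this aromatic carbon also reads alike stays open. So does the effect of a free hydroxy in place of the silyl ethers on the shared core.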